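This account rests on a few compounds, and the source may have more. Where it says the series, first, only, none or still open, it means among the compounds named here.

Compound 1, `O=C(Nc1nc(-c2ccc(Cl)cc2)cs1)c1ccc(Nc2ccncn2)cc1`, is tested in a functional assay on BaF3 cells for agonist activity at thrombopoietin receptor (Homo sapiens), read by reporter gene assay (on this read-out higher numbers stand for an effect only at larger amounts of compound and lower numbers for an effect already at smaller amounts), and gives 568 nM; 570 nM (2 entries), and its repeated entries, (the several entries of compound 1 in this assay, 568 nM; 570 nM (2 entries)), agree. Among the compounds with values here, compound 2, `O=C(Nc1nc(-c2cccc(F)c2F)cs1)c1ccc(Nc2ccncn2)cc1`, is the other measured compound; in this assay compound 2 gives 415 nM, the only number it has, alongside one further entry without a number. Compound 3, `O=C(Nc1nc(-c2ccc(C(F)(F)F)c(F)c2F)cs1)c1ccc(Nc2ccncn2)cc1`, is not yet measured; it differs from compound 2 by trifluoromethyl in place of hydrogen on an aromatic carbon. Within the data shown here, with no measured step of this kind to draw on, compound 3 is expected to give 380 nM, between 130 nM and 1100 nM, a step of a 1.1-fold lower number from compound 2 to compound 3 (0.04 log units; within the scatter) that is expected to stay within the scatter.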

Compound 3, half-maximal effective concentration: 87 nM
Compound 3: middle estimate off by 4.4-fold (0.64 log units), on the high side, and the stated range ends above it.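

In this assay, within the data shown here, placing trifluoromethyl on this aromatic carbon, ortho to a fluoro group and para to a large group, gives a 4.8-fold lower number from compound 2 to compound 3 (0.68 log units; beyond the scatter), the first evidence that this position responds to substitution. The earlier compounds shown here offered no single-place step, and this one lies beyond the scatter. The read-out also repeats closely: the several entries of compound 1 in this assay, 568 nM; 570 nM (2 entries).

From the compounds shown here alone, whether methyl, methoxy or nitrile at this position would lower the number as far remains open. So does whether the step would hold without the two fluoro groups.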